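Series notes: solubility across three measured sulfonamides

The compounds below may be only part of what the source reports. "The series", "measured", "known", "first", "only" and "open" are said of these compounds alone.

Measured so far:
- compound 1 `Cn1nccc1-c1cc(C(F)(F)F)ccc1[C@H]1CCOc2cc(S(=O)(=O)Nc3ccncn3)ccc21`: 1180000 nM
- compound 2 `O=S(=O)(Nc1nccs1)c1ccc2c(c1)OCC[C@@H]2c1ccc(C(F)(F)F)cc1N1CCNCC1`: 288000 nM
- compound 3 `Cc1ccc(-c2cc(C(F)(F)F)ccc2[C@H]2CCc3cc(S(=O)(=O)Nc4ncccn4)ccc32)cn1`: 47000 nM

In a physicochemical assay for solubility (on this read-out higher numbers stand for higher solubility and lower numbers for lower solubility), compound 2 stands second highest of the three; compound 1 sits higher by a step beyond the scatter, and compound 3 sits lower by a step also beyond the scatter.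

Compound 4 `O=S(=O)(Nc1nccs1)c1ccc2c(c1)OCC[C@@H]2c1ccc(C(F)(F)F)cc1-c1ccc(F)nc1` has not yet been measured. It differs from compound 2 in one place: 6-fluoropyridin-3-yl in place of piperazin-1-yl on an aromatic carbon

With the piperazin-1-yl gone and an aromatic ring in its place, a sizeable step downward in this assay is expected, in the direction of compound 3, which gives 47000 nM. The expected step is a 4.8-fold lower number from compound 2 to compound 4 (0.68 log units; beyond the scatter). For compound 4 the estimate is 60000 nM, with a range from 15000 nM to 250000 nM.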

Compound 4, solubility: 21000 nM
Compound 4: middle estimate off by 2.9-fold (0.46 log units), on the high side; the measured number falls inside the stated range.
By their numbers in this assay, from the lowest: compound 4; then compound 3; then compound 2; then compound 1.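

At this aromatic carbon, ortho to a large group and meta to a trifluoromethyl group, the series now has its first single-place comparison: in this assay, 6-fluoropyridin-3-yl in place of piperazin-1-yl gives a 14-fold lower number from compound 2 to compound 4 (1.14 log units; beyond the scatter). The position therefore matters to this read-out, which compound 1, compound 2 and compound 3 could not show, as they differ in more than one place. Nothing at hand accounts for the step.

This one swap does not separate the departure of piperazin-1-yl from the arrival of 6-fluoropyridin-3-yl. As far as these compounds go, how a carboxylic acid or an open-chain amine on this carbon would read remains open, as does whether the step carries over to the cores of compound 1 and compound 3.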